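Bis-enone series: benzyloxy removal and cytotoxicity

The source may report more compounds than this note shows. Statements on the series, on what has been measured and on what is new or still open speak of the compounds shown alone.

Measured so far in a functional assay on MDA-MB-231 cells (Homo sapiens) for cytotoxicity, read by MTT assay, with a stated time of 24 h; on this read-out lower numbers stand for stronger inhibition and higher numbers for weaker inhibition:
compound 1 `Cc1cc(O)c(C(=O)/C=C/c2ccc(Cl)cc2)c(-c2ccccc2)c1C(=O)/C=C/c1ccc(Cl)cc1`: 7900 nM
compound 2 `Cc1cc(O)c(C(=O)/C=C/c2ccc(Br)cc2)c(-c2ccc(OCc3ccccc3)cc2)c1C(=O)/C=C/c1ccc(Br)cc1`: 30000 nM
compound 3 `Cc1cc(O)c(C(=O)/C=C/c2ccc(Cl)cc2)c(-c2ccc(OCc3ccccc3)cc2)c1C(=O)/C=C/c1ccc(Cl)cc1`: 30000 nM

Compound 2 and compound 3 stand level at the digits printed, and together they give the highest numbers of the three. The difference between the two cores of compound 2 and compound 3 is not broken down here.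

Among the compounds with values here, the one structural change that has been measured is the step from compound 3 to compound 1: hydrogen in place of benzyloxy on an aromatic carbon. In this assay it gave a 3.8-fold lower number from compound 3 to compound 1 (0.58 log units; beyond the scatter), a modest shift but beyond the usual scatter.

Compound 4 `Cc1cc(O)c(C(=O)/C=C/c2ccc(Br)cc2)c(-c2ccccc2)c1C(=O)/C=C/c1ccc(Br)cc1` is not yet measured. It differs from compound 2 by the same kind of change: hydrogen in place of benzyloxy on an aromatic carbon. The two places are described in the same words, so the change is treated as the same one, made once on the core of compound 3 and once on the core of compound 2. Within the data shown here, since compound 2 and compound 3 give the same number at the digits printed, the expectation for compound 4 rests on the single measured step from compound 3 to compound 1; with only one example, the step could in principle be smaller or larger on this second core, and nothing in the data speaks to that. The estimated step from compound 2 to compound 4 is a 3.8-fold lower number from compound 2 to compound 4 (0.57 log units; beyond the scatter). On that basis compound 4 is expected to give about 8000 nM in this assay, with a plausible range from 3500 nM to 18000 nM.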

Compound 4, half-maximal inhibitory concentration: 10000 nM
Compound 4: middle estimate off by 1.3-fold (0.10 log units), on the low side; the measured number falls inside the stated range.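

In this assay, hydrogen in place of benzyloxy on an aromatic carbon gives a 3.0-fold lower number from compound 2 to compound 4 (0.48 log units; beyond the scatter), so the number falls on this second core as well. Set beside the earlier case, the change carries from one core to the other with the same direction and no gap in size beyond the scatter: the same change on two cores in this assay, a 3.8-fold lower number (0.58 log units; beyond the scatter) from compound 3 to compound 1 and a 3.0-fold lower number (0.48 log units; beyond the scatter) from compound 2 to compound 4, 1.3-fold (0.10 log units) apart, within the scatter of two such steps. Within the data shown here, this is agreement across only two pairs on two closely matched cores, in one cell line and at one stated time; it does not show why the number falls, and it does not show that the step would hold on a core that differs more widely.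

The compounds shown leave open whether the benzyloxy group must be removed entirely or whether a smaller group, such as a methoxy group, a hydroxyl group or an amine, could stand in its place on the aromatic carbon para to a large group with a similar result. They also leave open whether the step would survive if fluorine or a carboxylic acid replaced the chlorine and bromine carried by these compounds.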